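Swapping Chloro for Amino on a Purine-like Core

A few compounds are considered here, and "the series" means these few. Any claim that something is new, unique, unknown or untested is made for them only; others in the source may bear on it.

Measured compounds:
compound 1 `ClCc1ccccc1Cn1cnc2c(Cl)nc(Cl)nc21`, 2810 nM;
compound 2 `ClCc1cccc(Cn2cnc3c(Cl)nc(Cl)nc32)c1`, 3540 nM;
compound 3 `Nc1nc(Cl)c2ncn(Cc3ccccc3CCl)c2n1`, 19500 nM.

These three compounds were tested in a functional assay on OVCAR-8 cells (Homo sapiens) for cytotoxicity, read by sulforhodamine B assay, with a stated time of 48 h; a higher number here means a weaker inhibitor of growth, a lower number a stronger inhibitor of growth. Compound 1 and compound 2 share the same atoms joined differently; how their two cores differ is not broken down here, and their two values lie within the usual scatter of each other. Compound 3 carries the change amino in place of chloro on an aromatic carbon relative to compound 1, and that step, a 6.9-fold higher number from compound 1 to compound 3 (0.84 log units; beyond the scatter), weakened growth inhibition in this assay.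

Compound 4 `Nc1nc(Cl)c2ncn(Cc3cccc(CCl)c3)c2n1` is not yet measured. It differs from compound 2 by amino in place of chloro on an aromatic carbon, the same change, at a place described in the same words. Because a 6.9-fold higher number from compound 1 to compound 3 (0.84 log units; beyond the scatter) was seen once already, a step of similar size is expected from compound 2, namely a 6.8-fold higher number from compound 2 to compound 4 (0.83 log units; beyond the scatter). On that basis compound 4 is estimated to give 24000 nM in this assay, with an expected range from 10000 nM to 60000 nM, resting on a single earlier example of this change.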

Compound 4, concentration for total growth inhibition: 6760 nM
The estimate for compound 4 lay 3.6-fold (0.55 log units) above the measured number; the whole stated range lies above it.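

In this assay, putting amino in place of chloro on the second core gives a 1.9-fold higher number from compound 2 to compound 4 (0.28 log units; within the scatter), so on this core the effect of the change cannot be told apart from the ordinary spread of repeat measurements. The size of this change therefore did not carry over from one core to the other, and the two steps are clearly different: the same change on two cores in this assay, a 6.9-fold higher number (0.84 log units; beyond the scatter) from compound 1 to compound 3 and a 1.9-fold higher number (0.28 log units; within the scatter) from compound 2 to compound 4, 3.6-fold (0.56 log units) apart, beyond the scatter of two such steps. This shows that a step seen on one core is a weak guide to the step on a closely related core in this series, but two pairs do not show why the steps differ or what the change would do on any further core.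

The compounds shown leave open whether the gap between the two steps would also appear with another group in that place, such as methoxy or a dimethylamino group. They also leave open how much growth inhibition depends on the chloromethyl group, which a plain methyl group in its place could help to test.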